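From an Aminophenyl Limit to a Methoxyphenyl Estimate

The compounds below may be only part of what the source reports. "The series", "measured", "known", "first", "only" and "open" are said of these compounds alone.

In a functional assay on K562 cells (Homo sapiens) for antiproliferative activity, read by MTT assay, with a stated time of 72 h (on this read-out lower numbers stand for stronger inhibition and higher numbers for weaker inhibition), compound 1 (`COc1cc(-c2ncnn2-c2cccc(N)c2)cc(OC)c1OC`) gives > 10000 nM, which is a limit of the assay and not a number. Compound 2 (`COc1cc(-n2ncnc2-c2ccc(Cl)c(Cl)c2)cc(OC)c1OC`) gives > 10000 nM, which is also a limit. Compound 1 therefore stands at the limit of > 10000 nM in this assay, at which 2 of the 3 values shown sit. Among the measured compounds shown here, compound 3 (`CCOc1ccc(-c2ncnn2-c2cc(OC)c(OC)c(OC)c2)cc1`) supplies the only actual number, since in this assay compound 3 gives 20 nM.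

Compound 4 (`COc1ccc(-n2ncnc2-c2cc(OC)c(OC)c(OC)c2)cc1`) has 4-methoxyphenyl in place of 3-aminophenyl on an aromatic nitrogen of the core of compound 1, a change counted as 4-methoxyphenyl in place of 3-aminophenyl on an aromatic nitrogen. For the measured compounds named here, no measured step between the compounds shows directly what such a swap does, so any expectation is tentative. A move away from the limit of compound 1 is nevertheless expected. The scale of that move is judged against compound 3 at 20 nM in the same assay. The expected gain in potency, well beyond the scatter, is an at least 66-fold lower number from compound 1 to compound 4 (1.82 log units; beyond the scatter) as estimated. For compound 4 the estimated value is 150 nM, with an expected range from 10 nM to 5000 nM.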

Compound 4, half-maximal inhibitory concentration: 3600 nM
Compound 4: middle estimate off by 24-fold (1.38 log units), on the low side; the measured number falls inside the stated range.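

In this assay, among the compounds shown here, 4-methoxyphenyl in place of 3-aminophenyl on an aromatic nitrogen gives an at least 2.7-fold lower number from compound 1 to compound 4 (0.44 log units; beyond the scatter), the only step that can be read at this position, and it shows that this change brings the series from the limit to a measured number. The value of compound 1, > 10000 nM, is a limit of the assay and not a number. The true size of the step therefore remains unknown and could be larger than printed, because compound 1 sits at that limit: the limit of > 10000 nM in this assay, at which 2 of the 4 values shown sit.

The compounds shown leave open what a plain phenyl, a 4-aminophenyl or a 4-ethoxyphenyl would give on the same nitrogen. They also do not separate the loss of the amine from the gain of the methoxy group, which enter and leave together in this single step.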